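Dihalophenyl exchange on the amine nitrogen

The source may report more compounds than this note shows. Statements on the series, on what has been measured and on what is new or still open speak of the compounds shown alone.

Compound 1 `Cc1ccc(S(=O)(=O)/N=C(/CCNC2=CC(=O)c3ccccc3C2=O)Nc2ccccc2I)cc1` and compound 2 `Cc1ccc(S(=O)(=O)/N=C(/CCNC2=CC(=O)c3ccccc3C2=O)Nc2ccc(F)c(F)c2)cc1` share one core and differ only in the aryl group on the amine nitrogen. In a functional assay on DU-145 cells (Homo sapiens) for cytotoxicity, read by MTT assay, with a stated time of 48 h (on this read-out higher numbers stand for weaker inhibition and lower numbers for stronger inhibition), compound 1 gives 11700 nM and compound 2 gives 12900 nM; the step of a 1.1-fold higher number from compound 1 to compound 2 (0.04 log units; within the scatter) is small. Compound 2 thus stands at the upper end of the two numbers, with compound 1 within the scatter of it. Compound 3 `Cc1ccc(S(=O)(=O)/N=C(/CCNC2=CC(=O)c3ccccc3C2=O)Nc2ccc(Cl)cc2Cl)cc1` carries 2,4-dichlorophenyl in place of 3,4-difluorophenyl on an amine nitrogen. For the measured compounds named here, the only measured step that bears on this change is a 1.1-fold higher number from compound 1 to compound 2 (0.04 log units; within the scatter), one halogenated phenyl exchanged for another at the same nitrogen, which left the number where it was. Another halogenated phenyl at the same place is therefore expected to give no step beyond the scatter in this assay, in either direction. Compound 3 is expected to give about 12500 nM, with a range from 5500 nM to 28000 nM. The expected step, a 1.0-fold lower number from compound 2 to compound 3 (0.01 log units; within the scatter), lies within the scatter.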

Compound 3, half-maximal inhibitory concentration: 18600 nM
Compound 3: middle estimate off by 1.5-fold (0.17 log units), on the low side, within the range that was stated.
By their numbers in this assay, from the lowest: compounds 1, 2 and 3 (each within the scatter of the next).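

In this assay the exchange of 3,4-difluorophenyl for 2,4-dichlorophenyl on the amine nitrogen gives a 1.4-fold higher number from compound 2 to compound 3 (0.16 log units; within the scatter) and the exchange of 2-iodophenyl for the same group gives a 1.6-fold higher number from compound 1 to compound 3 (0.20 log units; within the scatter) in the same series. For the compounds shown here, all three halogenated phenyl groups at this place thus lie within the scatter of one another, which extends the single earlier step to a second halogen pattern and a third pair. The data give no explanation for these numbers.

The step from 3,4-difluorophenyl to 2,4-dichlorophenyl changes both the halogen and its placement on the ring, and these two changes cannot be told apart here. On these data alone, whether this flat reading extends beyond halogenated phenyl groups stays open, for example to a plain phenyl, a methoxyphenyl or a cyclohexyl group on the same nitrogen.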